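From 4-iodophenyl to 4-methylphenyl: working notes

The source may report more compounds than this note shows. Statements on the series, on what has been measured and on what is new or still open speak of the compounds shown alone.

Of the compounds shown here, two have values so far: compound 1 (`C=C1CCC[C@]2(C)CCC(C=O)=CC[C@@]12C`) and compound 2 (`C=C1CCC[C@]2(C)CCC(c3cn(-c4ccc(I)cc4)nn3)=CC[C@@]12C`). In a functional assay on B16 cells (Mus musculus) for cytotoxicity, read by MTT assay, with a stated time of 48 h (a lower number here means a stronger inhibitor, a higher number a weaker inhibitor), compound 1 gives 230000 nM and compound 2 gives 144000 nM. These two values lie within the scatter of each other, and they do not separate compound 2 from compound 1.

Next in line is compound 3 (`C=C1CCC[C@]2(C)CCC(c3cn(-c4ccc(C)cc4)nn3)=CC[C@@]12C`), where 4-iodophenyl becomes 4-methylphenyl: methyl in place of iodo on an aromatic carbon. This places methyl in place of iodo on an aromatic carbon, para to a large group. Among the measured compounds shown here, no measured pair differs in one place, and the data do not yet show what this swap does in this assay. The estimated step of a 1.1-fold higher number from compound 2 to compound 3 (0.05 log units; within the scatter) is expected to stay within the scatter, with neither direction favoured. Compound 3 is expected at 160000 nM, with an estimated range of 70000 nM to 350000 nM.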

Compound 3, half-maximal inhibitory concentration: 57600 nM
For compound 3 the middle estimate is 2.8-fold (0.44 log units) above the measured one, outside the stated range (below it).
By their numbers in this assay, from the lowest: compound 3; then compounds 2 and 1 (each within the scatter of the next).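

In this assay this aromatic carbon, para to a large group, proves sensitive to its substituent: methyl in place of iodo gives a 2.5-fold lower number from compound 2 to compound 3 (0.40 log units; beyond the scatter). Among the compounds shown here, this is the only single-place step so far, so the position's sensitivity rests on one pair and one modest change. No measurement of any property of either group accompanies the step, so its origin remains unassigned.

As far as these compounds go, whether a different group on this carbon, such as an amine, a carboxylic acid or a longer chain, would lower the number further, leave it unchanged or raise it remains open. Also open, from the compounds shown here alone, is whether the same change from 4-iodophenyl to 4-methylphenyl would give a similar step on a different core.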